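The compounds below may be only part of what the source reports. "The series", "measured", "known", "first", "only" and "open" are said of these compounds alone.

The measured compounds:
compound 1, `O=C(CN1CCN(c2cc(=O)[nH]c3ccc(F)cc23)CC1)Nc1nc(-c2ccccc2)cs1`, gives 7200 nM in a functional assay on T47D cells (Homo sapiens) for cytotoxicity, read by MTT assay, with a stated time of 3 h; a lower number here means a stronger inhibitor, a higher number a weaker inhibitor
compound 2, `Cc1ccc(-c2csc(NC(=O)CN3CCN(c4cc(=O)n(-c5ccccc5)c5ccccc45)CC3)n2)cc1`, gives 16500 nM
compound 3, `Cc1ccc(-c2csc(NC(=O)CN3CCN(c4cc(=O)[nH]c5ccc(F)cc45)CC3)n2)cc1`, gives 8410 nM

Compound 2 gives the highest of the three numbers in this assay; compound 3 lies within the scatter of it, while compound 1 lies beyond it. The unmeasured compound 4, `O=C(CN1CCN(c2cc(=O)n(-c3ccccc3)c3ccccc23)CC1)Nc1nc(-c2ccccc2)cs1`, differs from compound 2 by hydrogen in place of methyl on an aromatic carbon. For the measured compounds named here, one measured step bears on this change, run in the opposite direction on a different core: a 1.2-fold higher number from compound 1 to compound 3 (0.07 log units; within the scatter). That step stayed within the scatter, so the reverse change on the core of compound 2 is expected to move the number little, if anything slightly downward. Compound 4 is therefore estimated at 14000 nM, with a range from 6000 nM to 32000 nM. The step that this estimate means, a 1.2-fold lower number from compound 2 to compound 4 (0.07 log units; within the scatter), is expected to remain within the scatter.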

Compound 4, half-maximal inhibitory concentration: 10300 nM
Beside the measured number, compound 4's estimate is 1.4-fold (0.13 log units) above it, within the range that was stated.
By their numbers in this assay, from the lowest: compounds 1, 3, 4 and 2 (each within the scatter of the next, the first and the last beyond it).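

On the core of compound 2, in this assay, replacing the 4-methylphenyl with phenyl gives a 1.6-fold lower number from compound 2 to compound 4 (0.20 log units; within the scatter), so this position now has a second core on which the change stays within the scatter. Until now, the exchange of methyl and hydrogen on this aromatic carbon had been seen on the core of compound 1 alone. The two cores give steps that cannot be told apart, and on neither does the methyl shift the number beyond the scatter: the same change on two cores in this assay, a 1.2-fold higher number (0.07 log units; within the scatter) from compound 1 to compound 3 and a 1.6-fold higher number (0.20 log units; within the scatter) from compound 4 to compound 2, 1.4-fold (0.14 log units) apart, within the scatter of two such steps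

The compounds shown carry only hydrogen or methyl at this position, so it stays open whether a methoxy group, an amine or a carboxylic acid there would move the number in this assay beyond the scatter. Going by these compounds, the two cores differ in more than one place, so what each of those differences contributes also remains open.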